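The source may report more compounds than this note shows. Statements on the series, on what has been measured and on what is new or still open speak of the compounds shown alone.

Compound 1 `COc1cc2c(Nc3nc4ccc(C(=O)Nc5c(C)cccc5C)cc4s3)ncnc2cc1OCCCN1CCCC1` gives only a limit in a functional assay on DLD-1 cells (Homo sapiens) for cytotoxicity, read by WST assay, with a stated time of 72 h; a lower number here means a stronger inhibitor, a higher number a weaker inhibitor: > 100000 nM.
Compound 2 `COc1cc2c(Nc3nc4ccc(C(=O)Nc5c(C)cccc5C)cc4s3)ncnc2cc1OCCCN1CCCCC1` likewise gives only a limit in this assay: > 100000 nM.

For the measured compounds named here, compound 1 stands at a limit in this assay, and the one further value shown is a limit too (the limit of > 100000 nM in this assay, at which 2 of the 2 values shown sit). The step that the two limits leave unreadable from compound 1 to compound 2 therefore cannot be read. Compound 3 `COc1cc2c(Nc3nc4ccc(C(=O)Nc5c(C)cccc5Cl)cc4s3)ncnc2cc1OCCCN1CCCC1` differs from compound 1 by chloro in place of methyl on an aromatic carbon. Going by the values given here, no measured step bears on this change, so the step of a number no higher from compound 1 to compound 3 (the limit leaves the size open) is estimated without any readable precedent, and a limit again seems the most likely outcome. Compound 3 is expected at 100000 nM, within 20000 nM to 300000 nM.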

Compound 3, half-maximal inhibitory concentration: 60700 nM
Estimate against measurement, compound 3: 1.6-fold (0.22 log units) above, and the stated range covers the measured number.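

Moving from methyl to chloro on this aromatic carbon of the 2,6-dimethylphenyl group gives an at least 1.6-fold lower number from compound 1 to compound 3 (0.21 log units; that floor lies within the scatter) in this assay. For the compounds shown here, compound 3 therefore holds the only value shown that is a number, so this change takes the read-out off the limit, although the size of the step stays open. Compounds 1 and 2 remain at the limit: the limit of > 100000 nM in this assay, at which 2 of the 3 values shown sit.

The compounds shown leave open whether chloro has the same outcome with piperidin-1-yl in place of pyrrolidin-1-yl. They also leave open whether bromo or methoxy on this aromatic carbon would give a lower number still.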